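Oxime to ketone on the allyl trimethoxyphenyl triazole

A few compounds are considered here, and "the series" means these few. Any claim that something is new, unique, unknown or untested is made for them only; others in the source may bear on it.

Compound 3 `C=CCn1c(SC/C(=N/O)c2ccccc2)nnc1-c1cc(OC)c(OC)c(OC)c1` gives 77% in a functional assay on the whole organism (strain albino) for inhibition, with Rattus norvegicus as the target, read by paw edema, with a stated time of 5 h, at a dose of 0.28 mmol/kg by the oral route (on this read-out higher numbers stand for more inhibition at the one dose given (going by the name of the read-out) and lower numbers for less inhibition), and stands highest of the three measured numbers. Compound 1 `C=CCn1c(SCC(=O)c2ccccc2)nnc1-c1ccc(OC)c(OC)c1` gives 62%, lower by a margin beyond the scatter, and compound 2 `CCn1c(SCC(=O)c2ccccc2)nnc1-c1cc(OC)c(OC)c(OC)c1` gives 59%, the furthest below. Compound 4 `C=CCn1c(SCC(=O)c2ccccc2)nnc1-c1cc(OC)c(OC)c(OC)c1` is not yet measured. It differs from compound 3 in one place: a group of 8 heavy atoms (7 carbon, 1 oxygen; one six-membered aromatic ring of carbon only) in place of a group of 9 heavy atoms (7 carbon, 1 nitrogen, 1 oxygen; one six-membered aromatic ring of carbon only), on a saturated chain carbon bound to a sulfur. Going by the values given here, no measured pair shows this change directly. Compound 1 with 62% and compound 2 with 59% both carry the benzoyl group and lie within the scatter of each other. A downward step beyond the scatter is therefore expected, a number 15 percentage points lower from compound 3 to compound 4 (beyond the scatter). Compound 4 is estimated at 62% in this assay, within 50% to 73%.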

Compound 4, a percentage reported as inhibition, in the whole organism at one dose (the size of the read-out at that dose, not a potency): 60%
Compound 4: the middle estimate sits 2 percentage points above what was measured; measured number inside the range.
By their numbers in this assay, from the lowest: compounds 2, 4 and 1 (each within the scatter of the next); then compound 3.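

In this assay, going by these compounds alone, benzoyl in place of the oxime group on a saturated chain carbon bound to a sulfur gives a number 17 percentage points lower from compound 3 to compound 4 (beyond the scatter), the first direct reading of this change. With benzoyl held, vinyl in place of methyl on a saturated chain carbon bound to an aromatic nitrogen gives a number 1 percentage points higher from compound 2 to compound 4 (within the scatter), and methoxy in place of hydrogen on an aromatic carbon gives a number 2 percentage points lower from compound 1 to compound 4 (within the scatter), so among these compounds only the oxime change moves the number beyond the scatter. Nothing measured explains this step.

Open, on these data alone, is whether a methyl oxime ether or an amine on this carbon keeps the higher number. Also open, as far as these compounds go, is whether the vinyl and methoxy changes stay within the scatter with the oxime present.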